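This account rests on a few compounds, and the source may have more. Where it says the series, first, only, none or still open, it means among the compounds named here.

Working notes on the carbamate series.

Compound 1 `COC(=O)N1N=C(c2ccccc2)CC1c1cc(OC)c(OC)c(OC)c1` is the reference point. In a functional assay on MDA-MB-231 cells (Homo sapiens) for antiproliferative activity, read by MTT assay, with a stated time of 48 h (a higher number here means a weaker inhibitor of growth, a lower number a stronger inhibitor of growth), compound 1 gives 1080 nM. Compound 2 `CCOC(=O)N1N=C(c2ccccc2)CC1c1cc(OC)c(OC)c(OC)c1` carries the change methyl in place of hydrogen on a saturated chain carbon bound to an oxygen next to a carbonyl group and in this assay compound 2 gives 5610 nM; the step is a 5.2-fold higher number from compound 1 to compound 2 (0.72 log units; beyond the scatter). Compound 3 `CCOC(=O)N1N=C(c2cccc(OC)c2)CC1c1cc(OC)c(OC)c(OC)c1` adds a methoxy in place of hydrogen on an aromatic carbon, and in this assay compound 3 gives 9100 nM; the step is a 1.6-fold higher number from compound 2 to compound 3 (0.21 log units; within the scatter). The difference between the cores of compound 1 and compound 3 is not broken down here.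

Compound 4 `CCCOC(=O)N1N=C(c2cccc(OC)c2)CC1c1cc(OC)c(OC)c(OC)c1` is not yet measured. It differs from compound 3 by methyl in place of hydrogen on a saturated chain carbon, two bonds along the chain from an oxygen next to a carbonyl group. Within the data shown here, this is the same kind of change as the one from compound 1 to compound 2, but the place is not identical: in the earlier pair the carbon is bound to an oxygen next to a carbonyl group, whereas here it is two bonds along the chain from an oxygen next to a carbonyl group.

Among the measured compounds shown here, the one earlier instance of this kind of change lowered potency, as a 5.2-fold higher number from compound 1 to compound 2 (0.72 log units; beyond the scatter) shows, so a further weakening is the working expectation, though with only one precedent and a different place the size is uncertain. The expected step in this assay is a 1.8-fold higher number from compound 3 to compound 4 (0.25 log units; within the scatter), smaller than the earlier one because the earlier move already placed compound 3 at 9100 nM. The estimate for compound 4 in this assay is 16000 nM, between 6000 nM and 45000 nM.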

Compound 4, concentration for 50% growth inhibition: 12500 nM
Estimate against measurement, compound 4: 1.3-fold (0.11 log units) above; measured number inside the range.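

In this assay, the methyl on the saturated chain carbon, two bonds along the chain from an oxygen next to a carbonyl group, turns ethoxy into propoxy and gives a 1.4-fold higher number from compound 3 to compound 4 (0.14 log units; within the scatter), so on the core of compound 3 this change stays inside the usual scatter. Set beside the earlier methyl step, the change does not carry over at one size from one core to the other: the same change on two cores in this assay, a 5.2-fold higher number (0.72 log units; beyond the scatter) from compound 1 to compound 2 and a 1.4-fold higher number (0.14 log units; within the scatter) from compound 3 to compound 4, 3.8-fold (0.58 log units) apart, beyond the scatter of two such steps

This does not show what sets the two steps apart: they differ in the core and also in the place of the added methyl, and the compounds shown do not separate these two differences. Two pairs also give no general rule for the carbamate series.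

Open, as far as these compounds go, is how ethoxy to propoxy behaves on the core of compound 1, a comparison that would put the same change in the same place on both cores. Also open, from the compounds shown here alone, is whether a longer chain such as butoxy, or an amine at the end of the chain, would leave the number in this assay where compound 4 stands or move it beyond the scatter.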